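The source may hold more compounds than are shown below. What is called first, only, known or untested is meant among the compounds shown, and "the series" means these compounds.

The measured compounds:
- compound 1 `CC(C)N(Cc1cccc(OCCCCCC(=O)O)c1)C(=O)c1ccc(-c2ccc3[nH]ccc3c2)cc1`, which in an ADME assay on BJ cells (Homo sapiens) for cytotoxicity, read by CellTiter-Glo and resazurin assay, with a stated time of 72 h (on this read-out higher numbers stand for an effect only at larger amounts of compound and lower numbers for an effect already at smaller amounts), gives > 26000 nM; this value is a limit of the assay and not a number.
- compound 2 `CC(C)N(Cc1cccc(OCCCCCC(=O)O)c1)C(=O)c1ccc(-c2cc3ccccc3n2S(=O)(=O)c2ccccc2)cc1`, which in this assay gives > 26000 nM; this value is likewise a limit of the assay.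

Where compound 1 stands can therefore be said only in terms of that limit: it sits at the limit of > 26000 nM in this assay, at which 2 of the 2 values shown sit, and so does compound 2, so no ordering of the two can be read from these values.

The account now follows the step from compound 1 to the unmeasured compound 3 `CC(C)N(Cc1cccc(OCCCCCC(=O)O)c1)C(=O)c1ccc(-c2cccc([N+](=O)[O-])c2)cc1`. The change is 3-nitrophenyl in place of 1H-indol-5-yl on an aromatic carbon. Among the measured compounds shown here, since no step between two measured compounds is recorded in this assay, the size of the step cannot be taken from the data; the expectation is for no change beyond the scatter, with compound 3 expected to remain at the limit as compound 1 does.

On that basis compound 3 is estimated at 30000 nM, in a range from 10000 nM to 100000 nM, which would mean an expected step that the limit leaves unreadable from compound 1 to compound 3.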

Compound 3, half-maximal effective concentration: > 26000 nM
Compound 3: a limit, no number (the forecaster's own chance of this, stated with the estimate: 80%); the middle value does not contradict the limit.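

In this assay compound 3 gives > 26000 nM, which is a limit and not a number. Compound 1 also stands at a limit, so no step from compound 1 to compound 3 can be read: the limit of > 26000 nM in this assay, at which 3 of the 3 values shown sit.

The compounds shown leave open at what amount of compound any of them would have an effect, and whether their differing groups change it.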